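Chloro to hydrogen: compound 3 to compound 4

This account rests on a few compounds, and the source may have more. Where it says the series, first, only, none or still open, it means among the compounds named here.

Compound 3 `O=S(=O)(CC1=NCCS1)C1=NNCC1c1ccc(Cl)cc1` is reported in a functional assay, read by Griess assay, with a stated time of 150 min, tested at 75 ug/mL (on this read-out higher numbers stand for a stronger effect at the one concentration tested and lower numbers for a weaker effect), as "not active" (no number reported), so no single number stands behind it. Compound 2 `O=S(=O)(CC1=NCCO1)C1=NNCC1c1ccccc1` is the second entry of this kind: in this assay compound 2 likewise shows "not active" (no number reported), again without a number. The only numerical entry belongs to compound 1 `Cc1ccc(C2CNN=C2S(=O)(=O)CC2=NCCS2)cc1`, which in this assay gives 48.6%. Compound 3 therefore cannot be placed on the scale at all; compound 2 stands with it, and compound 1 is the sole measured reference.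

Compound 4 `O=S(=O)(CC1=NCCS1)C1=NNCC1c1ccccc1` differs from compound 3 in one place: hydrogen in place of chloro on an aromatic carbon. The shared core is otherwise retained. For the measured compounds named here, no pair of measured compounds differing in one place carries two numbers, so the recorded data give no size for such a change. Compound 2 also carries phenyl and reports no number. No move beyond the scatter is expected in this assay from compound 3 to compound 4. Compound 4 is estimated at 12%, with an expected range from 0% to 35%, and a report without a number is considered the more likely outcome.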

Compound 4, a percentage reported as activity, at one concentration (the size of the read-out at that concentration, not a potency): "not active" (no number reported)
Compound 4 has no reported number here; there is nothing to compare the estimate with.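

In this assay compound 3 gives "not active" (no number reported) and compound 4 gives "not active" (no number reported) so no step can be read between them. No evidence at hand bears on this result. The compounds shown leave open whether the change from 4-chlorophenyl to phenyl has any size on this read-out, where only compound 1 carries a number (48.6%)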